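Replacing nitro with fluoro on the sulfonyl aryl group

The source may report more compounds than this note shows. Statements on the series, on what has been measured and on what is new or still open speak of the compounds shown alone.

Measured in an ADME assay on cells (Hepatocyte, Mus musculus) for cytotoxicity, read by MTT assay, with a stated time of 24 h; on this read-out lower numbers stand for higher toxicity in this test and higher numbers for lower toxicity in this test:
- Compound 1 `Cc1ccc(-c2nn(-c3ccccc3)cc2-c2nc3ccccc3n2S(=O)(=O)c2ccc(F)cc2)cc1` gives 167000 nM
- Compound 2 `O=S(=O)(c1ccccc1)n1c(-c2cn(-c3ccccc3)nc2-c2ccc(F)cc2)nc2ccccc21` gives 231000 nM
- Compound 3 `O=[N+]([O-])c1ccc(S(=O)(=O)n2c(-c3cn(-c4ccccc4)nc3-c3ccc(F)cc3)nc3ccccc32)cc1` gives > 300000 nM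

Compound 3 stands at > 300000 nM, which is a limit of this assay and not a number. Compound 4 `O=S(=O)(c1ccc(F)cc1)n1c(-c2cn(-c3ccccc3)nc2-c2ccc(F)cc2)nc2ccccc21` differs from it by fluoro in place of nitro on an aromatic carbon. Among the compounds with values here, the one measured step that bears on this is an at least 1.2-fold higher number from compound 2 to compound 3 (0.11 log units; that floor lies within the scatter), for nitro in place of hydrogen. That step is small, so only a modest move to a lower number is expected, and the expected size is an at least 1.4-fold lower number from compound 3 to compound 4 (0.15 log units; that floor lies within the scatter). Compound 1 also carries the (4-fluorophenyl)sulfonyl group and gives 167000 nM, which supports this expectation. Compound 4 is estimated at 210000 nM, with an expected range from 120000 nM to 320000 nM.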

Compound 4, half-maximal cytotoxic concentration: 174000 nM
The estimate for compound 4 lay 1.2-fold (0.08 log units) above the measured number; the range from low to high includes it.
By their numbers in this assay, from the lowest: compounds 1, 4 and 2 (each within the scatter of the next). At a limit, above all of these: compound 3.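

In this assay, fluoro on the sulfonyl aryl ring gives a 1.3-fold lower number from compound 2 to compound 4 (0.12 log units; within the scatter), so this position now shows a hydrogen and a fluoro that cannot be told apart. Fluoro in place of methyl on the other aryl group gives a 1.0-fold higher number from compound 1 to compound 4 (0.02 log units; within the scatter), and the nitro to fluoro change gives an at least 1.7-fold lower number from compound 3 to compound 4 (0.23 log units; that floor lies within the scatter). Compound 3 stands at a limit and not a number, so that step has only a floor, and it does not establish a real effect of nitro: the limit of > 300000 nM in this assay, at which 1 of the 4 values shown sits. From the compounds shown here alone, it remains open how far compound 3 lies past its limit. Going by these compounds, whether an amine or a carboxylic acid at this position would move the number beyond the scatter also remains open.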